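Amide aryl swap and tolerated concentration in cytotoxicity

This account rests on a few compounds, and the source may have more. Where it says the series, first, only, none or still open, it means among the compounds named here.

Compound 1 `COc1cc2nc(SCC(=O)Nc3cccc(Cl)c3)nc(Nc3c(Cl)cc(/C=C/C#N)cc3Cl)c2cc1OC`: > 208000 nM
Compound 2 `COc1cc2nc([S+]([O-])CC(=O)Nc3ccccc3[N+](=O)[O-])nc(Nc3c(Cl)cc(/C=C/C#N)cc3Cl)c2cc1OC`: > 199000 nM

In an ADME assay on MT4 cells (Homo sapiens) for cytotoxicity, read by MTT assay, with a stated time of 5 days (a lower number here means that less compound is tolerated, a higher number that more compound is tolerated), compound 1 gives > 208000 nM, a limit of the assay rather than a number. Compound 2 gives > 199000 nM in this assay, likewise a limit. Going by the values given here, compound 2 thus stands at the limit of > 199000 nM in this assay, at which 1 of the 2 values shown sits, and the other value shown is also a limit, so no step between measured compounds can be drawn. Compound 3 `COc1cccc(NC(=O)C[S+]([O-])c2nc(Nc3c(Cl)cc(/C=C/C#N)cc3Cl)c3cc(OC)c(OC)cc3n2)c1` differs from compound 2 in one place: 3-methoxyphenyl in place of 2-nitrophenyl on an amide-type nitrogen. With nothing in the measured pair pointing either way, no shift beyond the scatter is expected in this assay. The expected step is a step that the limit leaves unreadable from compound 2 to compound 3. Compound 3 is estimated at 200000 nM, between 100000 nM and 400000 nM.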

Compound 3, half-maximal cytotoxic concentration: >= 167000 nM
Compound 3: only a limit was reported; the forecaster's own chance of this, stated with the estimate: 80%; the middle value is on the limit's open side.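

In this assay compound 3 gives >= 167000 nM, a limit and not a number. Compound 2 gives > 199000 nM, likewise a limit. Going by these compounds alone, no step can therefore be read between compound 2 and compound 3. Still open, as far as these compounds go, is whether 3-methoxyphenyl in place of 2-nitrophenyl changes the tolerated concentration at all.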